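The compounds below may be only part of what the source reports. "The series", "measured", "known", "first", "only" and "open" are said of these compounds alone.

Series notes. Of the compounds shown here, two have been measured so far. Compound 1 `CN1C(=O)C2=C(C1=O)N(CC(=O)Nc1ccc(-c3ccccc3)cn1)CCC2` gives 1 nM in an assay on cells for inhibition of Protein-serine O-palmitoleoyltransferase porcupine (Homo sapiens), read by reporter gene assay; on this read-out lower numbers stand for stronger inhibition and higher numbers for weaker inhibition. Compound 2 `CN1C(=O)C2=C(C1=O)N(CC(=O)Nc1ccc(-c3ccccn3)cc1)CCC2` gives 67 nM in this assay and thus stands at the highest of the two numbers seen, the gap to compound 1 lying beyond the scatter. The two differ in more than one place, so only their two values are set side by side here.

Compound 3 `CN1C(=O)C2=C(C1=O)N(CC(=O)Nc1ccc(-c3ccccc3)cc1)CCC2` is not yet measured. Against compound 2 the change is phenyl in place of pyridin-2-yl on an aromatic carbon. Among the measured compounds shown here, no single-point step between measured compounds exists to anchor an expectation, and the pair of compound 1 and compound 2 does not isolate this change. The expectation for compound 3 is a modest step downward from compound 2 in this assay, of about a 1.9-fold lower number from compound 2 to compound 3 (0.28 log units; within the scatter), though a step within the scatter is also plausible. Compound 3 is therefore estimated at 35 nM in this assay, with a range from 8 nM to 200 nM.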

Compound 3, half-maximal inhibitory concentration: 12 nM
For compound 3 the middle estimate is 2.9-fold (0.46 log units) above the measured one; the measured number falls inside the stated range.
By their numbers in this assay, from the lowest: compound 1; then compound 3; then compound 2.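

Among the compounds shown here, the first single-point step shows that this position is not indifferent to a small edit in this assay, as phenyl in place of pyridin-2-yl, on an aromatic carbon para to a large group, gives a 5.6-fold lower number from compound 2 to compound 3 (0.75 log units; beyond the scatter) in this series. The two groups match in ring size and in their 6 heavy atoms, so the edit amounts to one ring nitrogen exchanged for carbon, with 1 hydrogen-bond acceptor leaving and none entering. Nothing at hand explains the size of this step.

As far as these compounds go, whether the ring nitrogen counts at any placement remains open, since pyridin-3-yl and pyridin-4-yl would separate its presence from its location. Also open, from the compounds shown here alone, is how far this position tolerates a substituted ring, such as a phenyl carrying an amine or a carboxylic acid.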